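Moving the methylpyrazole attachment: compound 3 to compound 4

The source may hold more compounds than are shown below. What is called first, only, known or untested is meant among the compounds shown, and "the series" means these compounds.

In a functional assay on A2780 cells (Homo sapiens) for inhibition (a lower number here means a stronger inhibitor, a higher number a weaker inhibitor), compound 2 `CCNC(=O)c1noc(-c2cc(C(C)C)c(O)cc2O)c1-c1cc(C(N)=O)no1` gives 15 nM and compound 3 `CCNC(=O)c1noc(-c2cc(C(C)C)c(O)cc2O)c1-c1ccn(C)n1` gives 12 nM. These two values lie within the scatter of each other, so compound 3 stands level with compound 2. Compound 1 `CCNC(=O)c1noc(-c2cc(C(C)C)c(O)cc2O)c1-c1cc(CNCCO)no1` offers no comparison, its entry reading "not determined" (no result reported).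

The next compound, compound 4 `CCNC(=O)c1noc(-c2cc(C(C)C)c(O)cc2O)c1-c1cnn(C)c1`, carries 1-methyl-1H-pyrazol-4-yl in place of the 1-methyl-1H-pyrazol-3-yl of compound 3, on an aromatic carbon of a five-membered aromatic ring with 1 nitrogen and 1 oxygen: 1-methyl-1H-pyrazol-4-yl in place of 1-methyl-1H-pyrazol-3-yl on an aromatic carbon.

Within the data shown here, one measured step bears on this place: a 1.3-fold lower number from compound 2 to compound 3 (0.10 log units; within the scatter), which exchanged 3-carbamoyl-1,2-oxazol-5-yl for 1-methyl-1H-pyrazol-3-yl. Among the measured compounds shown here, no measured step compares two attachment points of the same pyrazole, so the expectation rests on that single step and stays wide. No change beyond the scatter is expected in this assay, and no direction is firmly indicated.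

The estimated step is a 1.3-fold higher number from compound 3 to compound 4 (0.10 log units; within the scatter).

For compound 4 the expected value is 15 nM, with an estimated range of 6 nM to 40 nM.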

Compound 4, half-maximal inhibitory concentration: 20 nM
Beside the measured number, compound 4's estimate is 1.3-fold (0.12 log units) below it; the measured number falls inside the stated range.
By their numbers in this assay, from the lowest: compounds 3, 2 and 4 (each within the scatter of the next).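

Moving the attachment point of the methylpyrazole is now measured directly: in this assay the change from 1-methyl-1H-pyrazol-3-yl to 1-methyl-1H-pyrazol-4-yl gives a 1.7-fold higher number from compound 3 to compound 4 (0.22 log units; within the scatter) and so does not separate the two isomers at this position. The comparison with 3-carbamoyl-1,2-oxazol-5-yl gives a 1.3-fold higher number from compound 2 to compound 4 (0.12 log units; within the scatter) and so places all three groups on this aromatic carbon level with one another, whichever pyrazole attachment is used. No supporting measurement accounts for this flat picture.

Still open, going by these compounds, is whether the same level holds for a plain phenyl ring, or for a ring carrying a carboxylic acid or a piperazine, at this position. Steps involving compound 1 cannot be read, so its hydroxyethylamino side chain adds nothing to the comparison.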